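This account rests on a few compounds, and the source may have more. Where it says the series, first, only, none or still open, it means among the compounds named here.

Working notes on the series in an ADME assay on a cell-free system (plasma, Rattus norvegicus) for metabolic stability, read by LC-MS, with a stated time of 60 min, at 37 degrees C, tested at 50 uM; on this read-out lower numbers stand for a less stable compound and higher numbers for a more stable compound.

Of the compounds shown here, three have been measured so far. Compound 1 `Cc1oc(=O)oc1COC(=O)C1=C(S[C@@H]2CN[C@H](C(=O)Nc3cccc(C(=O)OCc4oc(=O)oc4C)c3)C2)[C@H](C)[C@@H]2[C@@H]([C@@H](C)O)C(=O)N12` gives 0%. Compound 2 `C[C@@H](O)[C@H]1C(=O)N2C(C(=O)OCOC(=O)OC(C)(C)C)=C(S[C@@H]3CN[C@H](C(=O)Nc4cccc(C(=O)O)c4)C3)[C@H](C)[C@H]12` gives 0%. Compound 3 `C[C@@H](O)[C@H]1C(=O)N2C(C(=O)OCOC(=O)OC(C)(C)C)=C(S[C@@H]3CN[C@H](C(=O)Nc4cccc(C(=O)OCOC(=O)OC(C)(C)C)c4)C3)[C@H](C)[C@H]12` gives 8%. On the numbers shown, compound 2 stands level with compound 1 at the digits printed, and the two together are the lowest of the three readings; its furthest neighbour is compound 3, where the single measured step, a number 8 percentage points higher from compound 2 to compound 3 (within the scatter), is within the scatter. All three readings sit close to the bottom of the read-out.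

The next compound to be measured is compound 4 `COC(=O)OCOC(=O)C1=C(S[C@@H]2CN[C@H](C(=O)Nc3cccc(C(=O)O)c3)C2)[C@H](C)[C@@H]2[C@@H]([C@@H](C)O)C(=O)N12`. Against compound 2 the change is methyl in place of tert-butyl on an oxygen next to a carbonyl group, that is tert-butoxycarbonyl to methoxycarbonyl on an oxygen next to a carbonyl group. Among the measured compounds shown here, no measured step covers this change: the only step known, from compound 2 to compound 3, concerns a different replacement, and it did not move the reading beyond the scatter. With compound 2 at the floor of the read-out and nothing in the measured steps pointing upward, the working expectation is that compound 4 remains near that floor and that the expected step of a number 3 percentage points higher from compound 2 to compound 4 (within the scatter) is none beyond the scatter. Compound 4 is therefore estimated at 3%, with a range of 0% to 15%.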

Compound 4, percent of the compound remaining: 0%
Estimate against measurement, compound 4: 3 percentage points above, and the stated range covers the measured number.
By their numbers in this assay, from the lowest: compounds 1, 2, 4 and 3 (each within the scatter of the next).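

Methyl in place of tert-butyl on an oxygen next to a carbonyl group gives no change at the digits printed from compound 2 to compound 4 (within the scatter) in this assay, the first reading of any change at this place. Going from tert-butoxycarbonyl to methoxycarbonyl, a cut from 4 heavy atoms to 1 at the end of the group, therefore does not lift the reading off the bottom of the read-out, whereas the earlier compounds left this change untested. As both compounds sit at that bottom, the reading cannot show whether the change makes a compound any less stable, and nothing available explains the result.

Open, as far as these compounds go, is whether any other group on this oxygen, such as isopropyl, cyclohexyl or a longer chain ending in an amine, would bring the reading clear of the bottom of the read-out in this assay. Also open, from the compounds shown here alone, is whether compound 2 and compound 4 differ in how quickly they are lost within the stated time, which a single end-point reading at the bottom cannot separate.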